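The source may hold more compounds than are shown below. What is called first, only, known or untested is meant among the compounds shown, and "the series" means these compounds.

Measured compounds:

Compound 1, `Cc1ccccc1NS(=O)(=O)c1ccc(N2CCNC2=O)cc1`: in a functional assay on M21 cells (Homo sapiens) for antiproliferative activity, read by sulforhodamine B assay, with a stated time of 48 h (a lower number here means a stronger inhibitor, a higher number a weaker inhibitor), compound 1 gives 150 nM.
Compound 2, `O=C1NCCN1c1ccc(S(=O)(=O)Nc2ccc(OC(F)F)cc2)cc1`: in this assay compound 2 gives 410 nM.

Compound 1 holds the lowest of the two numbers in this assay; compound 2 sits higher, and the gap between them lies beyond the usual scatter. Both share the same core, and they differ in what sits on the anilide ring.

Compound 3, `O=C1NCCN1c1ccc(S(=O)(=O)Nc2ccccc2)cc1`, has not yet been measured in this assay. It differs from compound 1 by hydrogen in place of methyl on an aromatic carbon. Going by the values given here, no step between two measured compounds of this set covers a change of this kind, so nothing in the numbers so far fixes its size. The loss of a single carbon from an aromatic ring is a small change, and the step is expected to be modest, most likely toward a somewhat higher number, though a step of no size beyond the scatter would not surprise.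

Compound 3 is estimated at 250 nM, with a range from 100 nM to 650 nM, which means an expected step of a 1.7-fold higher number from compound 1 to compound 3 (0.22 log units; within the scatter).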

Compound 3, half-maximal inhibitory concentration: 200 nM
Beside the measured number, compound 3's estimate is 1.3-fold (0.10 log units) above it; the range from low to high includes it.
By their numbers in this assay, from the lowest: compounds 1 and 3 (each within the scatter of the next); then compound 2.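

In this assay the step reads a 1.3-fold higher number from compound 1 to compound 3 (0.12 log units; within the scatter), so on this aromatic carbon, ortho to a large group, methyl and hydrogen cannot be told apart, and the methyl of compound 1 is not required for activity at this level. Going by these compounds alone, the step of a 2.1-fold lower number from compound 2 to compound 3 (0.31 log units; beyond the scatter) gives the first one-place comparison that lies beyond the scatter: the phenyl of compound 3 and the difluoromethoxy-bearing ring of compound 2 can be told apart, though only modestly. Nothing measured here accounts for either step. Going by these compounds, whether an amine, a carboxylic acid or a chlorine in place of the methyl would hold the number of compound 1 remains open. So does whether a methoxy or a longer chain such as ethoxy would track with difluoromethoxy.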